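Replacing 4-cyanophenyl with 3-fluorophenyl in compound 3

This account rests on a few compounds, and the source may have more. Where it says the series, first, only, none or still open, it means among the compounds named here.

Measured so far in a functional assay on B16 cells (Mus musculus) for antiproliferative activity, read by MTT assay, with a stated time of 24 h; a higher number here means a weaker inhibitor, a lower number a stronger inhibitor:
- compound 1 `C#CCOc1ccc2c(=O)c(-c3cc(OC)c(OC)cc3OC)coc2c1`: 4500 nM
- compound 2 `COc1cc(OC)c(-c2coc3cc(OCc4ccccc4C(F)(F)F)ccc3c2=O)cc1OC`: 8550 nM
- compound 3 `COc1cc(OC)c(-c2coc3cc(OCc4ccc(C#N)cc4)ccc3c2=O)cc1OC`: 7000 nM

Compound 3 cannot be separated from the other two on these numbers. The steps that reach it are a 1.6-fold higher number from compound 1 to compound 3 (0.19 log units; within the scatter) and a 1.2-fold lower number from compound 2 to compound 3 (0.09 log units; within the scatter).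

Compound 4 `COc1cc(OC)c(-c2coc3cc(OCc4cccc(F)c4)ccc3c2=O)cc1OC` carries 3-fluorophenyl in place of 4-cyanophenyl on a saturated chain carbon bound to an oxygen on an aromatic ring. Within the data shown here, no compound with 3-fluorophenyl has been measured, so the only guide is the set of steps at this same place. The closest is the exchange of one substituted phenyl for another, a 1.2-fold lower number from compound 2 to compound 3 (0.09 log units; within the scatter). The step of a 1.9-fold higher number from compound 1 to compound 2 (0.28 log units; within the scatter) also stayed small, which leaves no measured direction to carry forward. No step beyond the scatter is therefore expected in this assay. The expected step is a 1.1-fold lower number from compound 3 to compound 4 (0.03 log units; within the scatter). Compound 4 is estimated at 6500 nM, with an expected range of 3500 nM to 12500 nM.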

Compound 4, half-maximal inhibitory concentration: 2440 nM
Compound 4: middle estimate off by 2.7-fold (0.43 log units), on the high side; measured number below the stated range.
By their numbers in this assay, from the lowest: compounds 4, 1, 3 and 2 (each within the scatter of the next, the first and the last beyond it).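

In this assay, this place on a saturated chain carbon bound to an oxygen on an aromatic ring now gives its first steps beyond the scatter (a 2.9-fold lower number from compound 3 to compound 4 (0.46 log units; beyond the scatter) and a 3.5-fold lower number from compound 2 to compound 4 (0.54 log units; beyond the scatter)), so exchanging one substituted phenyl for another can move the number here. Against ethynyl, 3-fluorophenyl stays within the scatter (a 1.8-fold lower number from compound 1 to compound 4 (0.27 log units; within the scatter)), so compound 4 separates from compound 2 and compound 3 but not from compound 1. No measurement shown offers an explanation for these steps.

As far as these compounds go, it remains open whether the separation belongs to 3-fluorophenyl alone or would also hold for unsubstituted phenyl or 4-fluorophenyl. From the compounds shown here alone, how an amine or a carboxylic acid carried on the chain at this place would read also remains open.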